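This account rests on a few compounds, and the source may have more. Where it says the series, first, only, none or still open, it means among the compounds named here.

Series notes. Compound 1 `O=C1/C(=C/c2cccc(Br)c2)NS(=O)(=O)c2ccccc21` and compound 2 `O=C1/C(=C/c2cccc(F)c2)NS(=O)(=O)c2ccccc21` have the shared core and differ only in the halogen on the aromatic ring. In an assay for inhibition of Intestinal-type alkaline phosphatase (Homo sapiens), read by spectrophotometry, with stated times of 10 min and 20 min (a lower number here means a stronger inhibitor, a higher number a weaker inhibitor), compound 1 gives 2550 nM, and compound 2 gives 9930 nM. Among the compounds with values here, the only measured comparison is a 3.9-fold higher number from compound 1 to compound 2 (0.59 log units; beyond the scatter). Compound 2 therefore stands at the highest of the two numbers, with compound 1 the nearest at the lower end. Compound 3 `O=C1/C(=C/c2ccc(F)cc2)NS(=O)(=O)c2ccccc21` is not yet measured. It differs from compound 2 by 4-fluorophenyl in place of 3-fluorophenyl on a double-bonded chain carbon bound to a double-bonded ring carbon; the two have the same atoms, joined differently. Within the data shown here, no measured step bears on this change: the one step available, fluoro in place of bromo, concerns a different halogen at an unchanged place, not a shift of the fluorophenyl pattern. Hence no step beyond the scatter is expected in this assay, in either direction, and the estimated step of a 1.1-fold lower number from compound 2 to compound 3 (0.04 log units; within the scatter) is expected to stay within it. Compound 3 is estimated at 9000 nM, with a range from 3000 nM to 27000 nM.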

Compound 3, half-maximal inhibitory concentration: 3060 nM
Compound 3: middle estimate off by 2.9-fold (0.47 log units), on the high side; low and high end bracket the measured number.
By their numbers in this assay, from the lowest: compounds 1 and 3 (each within the scatter of the next); then compound 2.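

Moving the fluorine is not a silent change: in this assay, 4-fluorophenyl in place of 3-fluorophenyl on a double-bonded chain carbon bound to a double-bonded ring carbon gives a 3.2-fold lower number from compound 2 to compound 3 (0.51 log units; beyond the scatter), so the arrangement of the aromatic ring counts at this place as well as the identity of the halogen. Set against the bromo compound, the same group gives a 1.2-fold higher number from compound 1 to compound 3 (0.08 log units; within the scatter), so a fluoro group does not by itself go with the higher number, and among these three only compound 2 stands apart. Nothing available explains this difference.

Still open, on these data alone, is whether the shift seen with fluoro also holds for bromo. As far as these compounds go, it is also open whether chloro, methoxy, an amine or a carboxylic acid on the aromatic ring would fall with compound 3 or with compound 2.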